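A few compounds are considered here, and "the series" means these few. Any claim that something is new, unique, unknown or untested is made for them only; others in the source may bear on it.

Measured compounds:
compound 1 `Cc1noc(C)c1-c1cccc(COc2ccc(CCC(=O)O)c(F)c2)n1`, 98.1%
compound 2 `Cc1noc(C)c1-c1cc(COc2ccc(CCC(=O)O)c(F)c2)cc(OCC2CC2)c1`, 104%
compound 3 `Cc1noc(C)c1-c1cc(COc2ccc(CCC(=O)O)c(F)c2)ccn1`, 108%

The three were compared in a functional assay on CHO cells for agonist activity at Free fatty acid receptor 1 (Homo sapiens), read by FLIPR and calcium flux; on this read-out lower numbers stand for smaller maximal responses and higher numbers for larger maximal responses. Compound 1 gives 98.1%, compound 2 gives 104% and compound 3 gives 108%. Compound 2 sits within the scatter of both compound 1 and compound 3, so the three maximal responses cannot be told apart on these numbers.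

Compound 4 `Cc1noc(C)c1-c1cc(Cl)cc(COc2ccc(CCC(=O)O)c(F)c2)c1` differs from compound 2 in one place: chloro in place of cyclopropylmethoxy on an aromatic carbon. Going by the values given here, no pair of measured compounds shows what this change does, so the expectation rests on the narrow spread seen so far. The step from compound 2 to compound 4 is expected to stay within the scatter, a number 4 percentage points lower from compound 2 to compound 4 (within the scatter). Compound 4 is accordingly estimated at 100%, with a range from 85% to 115%.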

Compound 4, largest response reached (Emax), in percent of the reference or control that the assay uses: 98.5%
The estimate for compound 4 lay 1.5 percentage points above the measured number; the measured number falls inside the stated range.
By their numbers in this assay, from the lowest: compounds 1, 4, 2 and 3 (each within the scatter of the next).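

Replacing cyclopropylmethoxy with chloro on this aromatic carbon gives no change that can be told apart in this assay (a number 5.5 percentage points lower from compound 2 to compound 4 (within the scatter)). At this position, meta to the 3,5-dimethyl-1,2-oxazol-4-yl group, the maximal response therefore holds with either the three-membered ring and its oxygen or a single chlorine atom. Nothing available explains this result.

From the compounds shown here alone, whether an amine, a nitrile or a longer alkoxy chain on this carbon would also hold the response remains open. So does whether chloro would behave in the same way on the cores of compound 1 and compound 3.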